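What a nitro group might do to compound 1

The source may hold more compounds than are shown below. What is called first, only, known or untested is meant among the compounds shown, and "the series" means these compounds.

Compound 1 `O=C(CCCCC(S)CCS)Nc1ccccc1` gives 7.67%
Compound 2 `O=C(CCCCC(S)CCS)Nc1cccc(Cl)c1` gives 16.1%
Compound 3 `Cc1cccc(NC(=O)CCCCC(S)CCS)c1` gives 7.08%

These numbers come from a functional assay on Bel-7402 cells (Homo sapiens) for inhibition, read by MTT assay, with a stated time of 24 h, tested at 100 ug/mL (a lower number here means less inhibition of growth, a higher number more inhibition of growth at the concentration tested), and compound 1 lies within the scatter of both compound 2 and compound 3, so the three cannot be ranked. Compound 4 `O=C(CCCCC(S)CCS)Nc1ccc([N+](=O)[O-])cc1` is still unmeasured. It differs from compound 1 by nitro in place of hydrogen on an aromatic carbon, para to a large group (nitro in place of hydrogen on an aromatic carbon).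

Among the compounds with values here, two measured steps bear on this change, each placing a group on an aromatic carbon. They are a number 8.4 percentage points higher from compound 1 to compound 2 (within the scatter) for chloro and a number 0.6 percentage points lower from compound 1 to compound 3 (within the scatter) for methyl, and both stay within the scatter. Within the data shown here, no measured compound carries a nitro group, so this is only a loose guide. No step beyond the scatter is expected, and the estimate is a number 3.3 percentage points higher from compound 1 to compound 4 (within the scatter) in this assay with its direction unsettled. For compound 4 the expected value is 11% (estimated range 3% to 22%).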

Compound 4, percent growth inhibition at one concentration: 33.4%
Compound 4: middle estimate off by 22.4 percentage points, on the low side; measured number outside the range, above it.
By their numbers in this assay, from the lowest: compounds 3, 1 and 2 (each within the scatter of the next); then compound 4.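

Adding a nitro group to the ring, para to a large group, gives a number 25.7 percentage points higher from compound 1 to compound 4 (beyond the scatter) in this assay. Within the data shown here, this is the only change on this ring so far to move growth inhibition beyond the scatter, which the chloro and methyl steps did not do, so the ring does not tolerate every group with the same result. No measured evidence here explains the gain.

From the compounds shown here alone, whether the gain belongs to the nitro group itself or to the place it occupies stays open. An amine or a carboxylic acid on this same carbon would help to separate the two.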